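The source may hold more compounds than are shown below. What is called first, only, known or untested is meant among the compounds shown, and "the series" means these compounds.

Working notes on the series.

Compound 1 `O=C(Nc1cnc(NCc2c(F)ccc3c2CCO3)n2cnnc12)c1ccccc1` is the reference for the amide branch of the shared core. In an ADME assay on microsomes from liver (Homo sapiens) for metabolic stability, read by LC-MS, using NADPH, with stated times of 5 min and 30 min, tested at 1 uM (on this read-out lower numbers stand for slow clearance and higher numbers for fast clearance), compound 1 gives 10 mL.min-1.g-1, the lowest of the three numbers measured. Compound 2 `CN(c1cccnc1)c1cnc(NCc2c(F)ccc3c2CCO3)n2cnnc12` gives 80 mL.min-1.g-1, and the step of an 8.0-fold higher number from compound 1 to compound 2 (0.90 log units; beyond the scatter) is the only one beyond the scatter that starts from compound 1. Compound 3 `CN(c1ccn(C)n1)c1cnc(NCc2c(F)ccc3c2CCO3)n2cnnc12` gives 11 mL.min-1.g-1, and the step of a 1.1-fold higher number from compound 1 to compound 3 (0.04 log units; within the scatter) leaves compound 1 and compound 3 indistinguishable; the step of a 7.3-fold lower number from compound 2 to compound 3 (0.86 log units; beyond the scatter) separates the two amine analogues.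

Compound 4 `CN(C)Cc1ccc(C(=O)Nc2cnc(NCc3c(F)ccc4c3CCO4)n3cnnc23)cc1` keeps the benzamide of compound 1 and differs from it only by the change ((dimethylamino)methyl in place of hydrogen on an aromatic carbon). Among the measured compounds shown here, none of the measured steps touches this position: each of them exchanges or alters the whole substituent on the core rather than decorating the phenyl ring of the amide. For the measured compounds named here, with no step on this ring to lean on, no change beyond the scatter is expected, with a small margin for a higher number. Compound 4 is therefore estimated at 14 mL.min-1.g-1, range 6 mL.min-1.g-1 to 35 mL.min-1.g-1, which means an expected step of a 1.4-fold higher number from compound 1 to compound 4 (0.15 log units; within the scatter).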

Compound 4, intrinsic clearance in microsomes: 13 mL.min-1.g-1
Compound 4: middle estimate off by 1.1-fold (0.03 log units), on the high side, within the range that was stated.
By their numbers in this assay, from the lowest: compounds 1, 3 and 4 (each within the scatter of the next); then compound 2.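

The phenyl ring of the benzamide accepts (dimethylamino)methyl in place of hydrogen, on the aromatic carbon para to a large group, without a change that can be told from the scatter in this assay, with a 1.3-fold higher number from compound 1 to compound 4 (0.11 log units; within the scatter) as the step. Among the compounds shown here, this is the first measured step that keeps the amide and decorates its phenyl ring, where the earlier steps exchanged or altered the whole substituent on the core, so this position now has one reading, from a single pair. No measurement shown gives a reason for this outcome.

From the compounds shown here alone, whether a carboxylic acid, a morpholine ring or a longer amine chain on this same carbon would leave the number equally undisturbed remains open. Also open, going by these compounds, is whether (dimethylamino)methyl on another carbon of the phenyl ring would read the same.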